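Ethyl to Hydroxy on the Side Chain of Compound 1

A few compounds are considered here, and "the series" means these few. Any claim that something is new, unique, unknown or untested is made for them only; others in the source may bear on it.

Compound 1 `CC[C@H](C)[C@H](NC(=O)CN(c1nc(Cl)nc2[nH]cnc12)C1CC1)C(=O)OCc1ccccc1` was tested in a functional assay on the whole organism (Tail, strain ICR) with Mus musculus as the target, in the tail flick test, with a stated time of 60 min, at a dose of 25 umol/kg by the oral route (a higher number here means a stronger effect of the compound at the dose given, a lower number a weaker effect), where compound 1 gives 40.6%. Its companion, compound 2 `CC(C)[C@H](NC(=O)CN(c1ncnc2c1ncn2C1CCCCO1)C1CC1)C(=O)OCc1ccccc1`, gives 34.9% in this assay, a result that lies within the usual scatter of the value for compound 1. Compound 3 `C[C@@H](O)[C@H](NC(=O)CN(c1nc(Cl)nc2[nH]cnc12)C1CC1)C(=O)OCc1ccccc1` has not been measured in this assay. It differs from compound 1 in one place: hydroxy in place of ethyl on a saturated chain carbon bound to two saturated chain carbons. For the measured compounds named here, no measured pair shows this change, so a step of a number 7.6 percentage points lower from compound 1 to compound 3 (within the scatter) is expected, most likely a modest loss or none beyond the scatter. For compound 3, a result of 33% is estimated, between 15% and 55%.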

Compound 3, a percentage reported as activity, at one dose (the size of the read-out at that dose, not a potency): 29.7%
Compound 3: middle estimate off by 3.3 percentage points, on the high side; low and high end bracket the measured number.
By their numbers in this assay, from the lowest: compounds 3, 2 and 1 (each within the scatter of the next, the first and the last beyond it).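

The change of ethyl to hydroxy on a saturated chain carbon bound to two saturated chain carbons gives, in this assay, a number 10.9 percentage points lower from compound 1 to compound 3 (beyond the scatter), the first step read at this position. The change from sec-butyl to 1-hydroxyethyl therefore lowers the read-out at this dose without removing it, as compound 3 still gives 29.7%. Nothing available accounts for this loss. As far as these compounds go, whether a methoxy group, an amine or a longer chain at this carbon would keep the level of compound 1 remains open. So does whether the same step recurs on a different core.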